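Dropping the 5-methylpyridin-2-yl group from compound 1

The source may report more compounds than this note shows. Statements on the series, on what has been measured and on what is new or still open speak of the compounds shown alone.

In an ADME assay on a cell-free system (plasma, Homo sapiens) for protein binding, compound 1 (`Cc1ccc([C@@H](C)Oc2cc3oc(=O)n(CCC(=O)O)c3cc2Cl)nc1`) gives 97.8%. Compound 2 (`O=C(O)CCn1c(=O)oc2cc(Cl)c(Cl)cc21`) gives 98.2%, within the scatter of the first, while compound 3 (`C[C@@H](Oc1cc2oc(=O)n(CCC(=O)O)c2cc1Cl)c1cccnn1`) gives 68.1%. Compound 4 (`CCOc1cc2oc(=O)n(CCC(=O)O)c2cc1Cl`), still unmeasured, has hydrogen in place of 5-methylpyridin-2-yl on a saturated chain carbon bound to an oxygen on an aromatic ring and a saturated chain carbon. Within the data shown here, the only measured step at this place, a 15-fold higher unbound fraction from compound 1 to compound 3 (1.16 log units; beyond the scatter), is large, but it swaps one ring for another rather than removing it. Compound 2 lacks that group yet gives 98.2%, so only a modest shift towards more free compound is expected. The expected step is a 2.3-fold higher unbound fraction from compound 1 to compound 4 (0.36 log units; beyond the scatter). For compound 4 the estimate in this assay is 95%, ranging from 86% to 98.5%.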

Compound 4, plasma protein binding: 95.8%
Compound 4: the middle estimate sits 1.2-fold (0.08 log units) (unbound fraction) above what was measured; low and high end bracket the measured number.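

In this assay hydrogen in place of 5-methylpyridin-2-yl gives a 1.9-fold higher unbound fraction from compound 1 to compound 4 (0.28 log units; within the scatter) so this ring can go without a clear change in binding. Hydrogen in place of pyridazin-3-yl gives a 7.6-fold lower unbound fraction from compound 3 to compound 4 (0.88 log units; beyond the scatter) so of the three groups compared at this place, pyridazin-3-yl alone stands apart. Ethoxy in place of chloro on an aromatic carbon gives a 2.3-fold higher unbound fraction from compound 2 to compound 4 (0.37 log units; beyond the scatter) and so is a modest step towards more unbound compound.

Going by these compounds, whether a longer chain or a ring carrying an amine at this place would behave like pyridazin-3-yl stays open. Nothing measured here gives a reason for these steps.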